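Shrinking the terminal ring from cyclopentyl to cyclopropyl

This account rests on a few compounds, and the source may have more. Where it says the series, first, only, none or still open, it means among the compounds named here.

Measured compounds:
compound 1, `COC(=O)CC/C=C\CC[C@H]1C(=O)C[C@@H](O)[C@@H]1/C=C/C[C@@](C)(O)/C=C/C1=CCCC1`, 0.00002 mg/kg
compound 2, `COC(=O)CC/C=C\CC[C@H]1C(=O)C[C@@H](O)[C@@H]1/C=C/CC(C)(O)CCC1CCCC1`, 0.00009 mg/kg

In a functional assay on the whole organism (stomach) with Canis familiaris (Canis lupus familiaris) as the target (on this read-out higher numbers stand for an effect only at larger amounts of compound and lower numbers for an effect already at smaller amounts), compound 1 gives 0.00002 mg/kg, and compound 2 gives 0.00009 mg/kg. Within the data shown here, compound 2 thus has the highest number of the two, with compound 1 as its only neighbour. Among the measured compounds shown here, the one measured step, a 4.5-fold higher number from compound 1 to compound 2 (0.65 log units; beyond the scatter), changes the same side chain but not the ring size, so it bears only loosely on the step now considered.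

Compound 3, `COC(=O)CC/C=C\CC[C@H]1C(=O)C[C@@H](O)[C@@H]1/C=C/CC(C)(O)CCC1CC1`, differs from compound 2 by cyclopropyl in place of cyclopentyl on a saturated chain carbon, three bonds along the chain from an oxygen on a saturated carbon. For the measured compounds named here, no measured pair shows what a smaller ring at this place does. Going by the values given here, since the sole step was modest, only a small step is expected here, if any beyond the scatter, leaning toward a slightly higher number: compound 3 is estimated at 0.00015 mg/kg in this assay, within 0.00004 mg/kg to 0.0006 mg/kg, which would mean an expected 1.7-fold higher number from compound 2 to compound 3 (0.22 log units; within the scatter).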

Compound 3, dose for half-maximal effect: 0.00009 mg/kg
Beside the measured number, compound 3's estimate is 1.7-fold (0.22 log units) above it, and the stated range covers the measured number.
By their numbers in this assay, from the lowest: compound 1; then compounds 2 and 3 (each within the scatter of the next).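

In this assay, the ring size at this place, on a saturated chain carbon three bonds along the chain from an oxygen on a saturated carbon, made no visible difference between these two rings, with no change at the digits printed from compound 2 to compound 3 (within the scatter). The distance to compound 1 also stays as it was with the smaller ring, at a 4.5-fold higher number from compound 1 to compound 3 (0.65 log units; beyond the scatter), so the cyclopropyl compound keeps the same separation from the unsaturated side chain of compound 1 as the cyclopentyl compound did. No measurement is available that would explain why the two rings read alike.

The compounds shown cover only a three-membered and a five-membered carbon ring on this saturated chain. They leave open whether a phenyl ring, a primary amine or a plain longer chain at this place would give a similar number.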